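Chloro for fluoro on the urea phenyl: compound 4

The source may hold more compounds than are shown below. What is called first, only, known or untested is meant among the compounds shown, and "the series" means these compounds.

Three compounds carry measurements in a functional assay on MKN-45 cells (Homo sapiens) for cytotoxicity, read by MTT assay, with a stated time of 72 h; a higher number here means a weaker inhibitor, a lower number a stronger inhibitor. Compound 2 `CN(C)CCNc1nc(-c2ccc(NC(=O)Nc3ccc(F)cc3)cc2)nc2ccsc12` gives 330 nM and stands lowest of the three; compound 1 `CN(C)CCCNc1nc(-c2ccc(NC(=O)Nc3ccccc3Cl)cc2)nc2ccsc12` gives 690 nM, a gap beyond the scatter, and compound 3 `Cc1ccc(NC(=O)Nc2ccc(-c3nc(NCCCN(C)C)c4sc(Cl)c(Cl)c4n3)cc2)cc1` gives 3700 nM, far beyond it. Among these three, compound 2 is the strongest inhibitor.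

Compound 4 `CN(C)CCNc1nc(-c2ccc(NC(=O)Nc3ccc(Cl)cc3)cc2)nc2ccsc12` is not yet measured. It differs from compound 2 by chloro in place of fluoro on an aromatic carbon, para to a large group, so that the (4-fluorophenyl)carbamoyl group becomes (4-chlorophenyl)carbamoyl. Within the data shown here, no measured pair shows this exact exchange, so the size of the step cannot be read from the series and has to be estimated. Such an exchange is expected to move the number little, and the step is estimated at a 1.3-fold lower number from compound 2 to compound 4 (0.10 log units; within the scatter), which lies within the scatter. Compound 4 is therefore expected to give about 260 nM in this assay, with a range from 110 nM to 650 nM.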

Compound 4, half-maximal inhibitory concentration: 250 nM
The estimate for compound 4 lay 1.0-fold (0.02 log units) above the measured number; measured number inside the range.
By their numbers in this assay, from the lowest: compounds 4 and 2 (each within the scatter of the next); then compound 1; then compound 3.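

Among these compounds, this is the first step that can be read at a single place, as the earlier compounds differ from one another in more than one place. In this assay, chloro in place of fluoro on the aromatic carbon of the urea phenyl gives a 1.3-fold lower number from compound 2 to compound 4 (0.12 log units; within the scatter), so compound 2 and compound 4 cannot be told apart, and at this place the two halogens are interchangeable as far as this read-out shows. No measurement is at hand that bears on the reason for this result.

On these data alone, whether a larger or differently charged group at this place, such as methoxy, a carboxylic acid or a primary amine, would stay as close to compound 2 remains open. Steps to compound 1 and compound 3 cannot be read, so the separate contributions of the side chain and the ring chloro groups also stay open.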